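Cytotoxicity notes: chloro removed from the benzyl group

A few compounds are considered here, and "the series" means these few. Any claim that something is new, unique, unknown or untested is made for them only; others in the source may bear on it.

Three compounds have been run in an ADME assay on HEL cells (Homo sapiens) for cytotoxicity, with a stated time of 3 days (on this read-out lower numbers stand for higher toxicity in this test and higher numbers for lower toxicity in this test), so far, and none returned a number. Compound 1 `CC1(C(c2ccccc2)c2ccccc2)OS(=O)(=O)C=C1OCc1ccccc1` gives >= 400000 nM, a limit of the test rather than a measured value. Compound 2 `CCC1(Cc2ccccc2)OS(=O)(=O)C=C1OCc1ccc(Cl)cc1` gives >= 50000 nM in this assay, likewise a limit. Compound 3 `CCC1(Cc2ccccc2)OS(=O)(=O)C=C1OCCCCCCc1ccccc1` gives >= 20000 nM in this assay, again a limit. Compound 2 thus stands at the limit of >= 50000 nM in this assay, at which 1 of the 3 values shown sits. The two other entries sit at the limit of >= 400000 nM in this assay, at which 1 of the 3 values shown sits, and at the limit of >= 20000 nM in this assay, at which 1 of the 3 values shown sits. Every value is a limit. Among the measured compounds shown here, no order among the three can be read, and no step between measured compounds is available.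

Compound 4 `CCC1(Cc2ccccc2)OS(=O)(=O)C=C1OCc1ccccc1` is the next entry. Against compound 2 the change is hydrogen in place of chloro on an aromatic carbon. The chloro is lost from the benzyl ether and nothing else moves. With all three measured compounds at limits and no cytotoxicity seen in any of them, the expected step is a number no higher from compound 2 to compound 4 (the limit leaves the size open), that is none beyond the scatter, most likely ending in another limit rather than a measured concentration. Compound 4 is expected to give 50000 nM in this assay. The expected range for compound 4 runs from 20000 nM to 400000 nM.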

Compound 4, minimum cytotoxic concentration: >= 50000 nM
Compound 4: only a limit was reported; the forecaster's own chance of this, stated with the estimate: 85%; the middle value lies on the limit itself.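

Among the compounds shown here, compound 2 and compound 4 both stand at limits in this assay, so the step from 4-chlorobenzyl to benzyl cannot be read and this pair adds no new step. The compounds shown leave open whether that change moves the minimum cytotoxic concentration at all, and at what concentration any of the four would show toxicity.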